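The compounds below may be only part of what the source reports. "The series", "measured", "known", "first", "only" and "open" are said of these compounds alone.

Within the data shown here, compound 1 `Nc1ncnc2c1c(-c1cc(C3CC3)on1)nn2C1CCCCC1` holds the only number measured in an assay on BaF3 cells for inhibition of proto-oncogene tyrosine-protein kinase receptor Ret (Homo sapiens), read by MTT assay, with a stated time of 48 h; on this read-out higher numbers stand for weaker inhibition of growth and lower numbers for stronger inhibition of growth: compound 1 gives 520 nM. Compound 2 `CC(C)n1nc(/C=N/O)c2c(N)ncnc21` stands at a limit of the assay rather than at a number, in this assay compound 2 giving > 10000 nM (the limit of > 10000 nM in this assay, at which 1 of the 2 values shown sits). Compound 3 `Cn1nc(-c2cc(C3CC3)on2)c2c(N)ncnc21` is not yet measured; it differs from compound 1 by methyl in place of cyclohexyl on an aromatic nitrogen. Among the measured compounds shown here, no measured pair shows this exchange, so the expected step from compound 1 to compound 3 in this assay is a weakening beyond the scatter, a 9.6-fold higher number from compound 1 to compound 3 (0.98 log units; beyond the scatter). Compound 3 is estimated at 5000 nM, expected between 1500 nM and 15000 nM.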

Compound 3, concentration for 50% growth inhibition: 2670 nM
Beside the measured number, compound 3's estimate is 1.9-fold (0.27 log units) above it; the measured number falls inside the stated range.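

In this assay, among these compounds, the first measured step at this position, methyl in place of cyclohexyl on the aromatic nitrogen, gives a 5.1-fold higher number from compound 1 to compound 3 (0.71 log units; beyond the scatter) and so weakens growth inhibition. Compound 3 still gives a number rather than a limit of the assay, so the cyclohexyl ring is not needed for a measurable value. Nothing measured here accounts for the size of this step.

Among the compounds shown here, with only two groups compared on this nitrogen, it stays open how an ethyl, cyclopentyl or phenyl group would fall. As far as these compounds go, the effect of replacing the 5-cyclopropyl-1,2-oxazol-3-yl group also stays open.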